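From 6-chloropyridin-3-yl to 6-methoxypyridin-3-yl

This account rests on a few compounds, and the source may have more. Where it says the series, first, only, none or still open, it means among the compounds named here.

In a functional assay on MCF7 cells (Homo sapiens) for inhibition, read by MTT assay, with a stated time of 48 h (on this read-out higher numbers stand for weaker inhibition of growth and lower numbers for stronger inhibition of growth), compound 1 (`Cn1cc(C2CC(c3ccccc3)=NN2C(=O)c2cccnc2)c2ccccc21`) gives 7200 nM and compound 2 (`Cn1cc(C2CC(c3ccccc3)=NN2C(=O)c2ccc(Cl)nc2)c2ccccc21`) gives 9250 nM. Going by the values given here, compound 2 therefore stands within the scatter of compound 1, the only other measured compound.

The next change leads to compound 3 (`COc1ccc(C(=O)N2N=C(c3ccccc3)CC2c2cn(C)c3ccccc23)cn1`): methoxy in place of chloro on an aromatic carbon, next to the ring nitrogen and para to a large group (methoxy in place of chloro on an aromatic carbon). Among the compounds with values here, one measured step bears on this carbon, the exchange of hydrogen for chloro, a 1.3-fold higher number from compound 1 to compound 2 (0.11 log units; within the scatter). Within the data shown here, no measured compound carries methoxy, so this single step is a thin guide. With that step inside the scatter, no shift beyond the scatter is expected in this assay, and the expected step is a 1.2-fold lower number from compound 2 to compound 3 (0.06 log units; within the scatter). For compound 3 the estimated value is 8000 nM, with an expected range of 3800 nM to 17000 nM.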

Compound 3, concentration for 50% growth inhibition: 4310 nM
Compound 3: the middle estimate sits 1.9-fold (0.27 log units) above what was measured, and the stated range covers the measured number.
By their numbers in this assay, from the lowest: compounds 3, 1 and 2 (each within the scatter of the next, the first and the last beyond it).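

Going by these compounds alone, on the aromatic carbon next to the ring nitrogen, methoxy in place of chloro gives the first step beyond the scatter in this assay, a 2.1-fold lower number from compound 2 to compound 3 (0.33 log units; beyond the scatter), though the step is modest. Against the unsubstituted compound the same carbon shows no such separation, with methoxy in place of hydrogen giving a 1.7-fold lower number from compound 1 to compound 3 (0.22 log units; within the scatter), so only the chloro and methoxy compounds are told apart, and hydrogen does not separate from either. The data shown offer no explanation for the difference between chloro and methoxy.

The compounds shown leave open whether ethoxy, a longer chain on the same oxygen, or an amine such as dimethylamino on this carbon would move the number further. They also leave open whether the step from chloro to methoxy holds on a different core.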